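The source may hold more compounds than are shown below. What is called first, only, known or untested is meant among the compounds shown, and "the series" means these compounds.

Compound 1 `CN1C(=O)NC2(CC2(C)C)C1=O` stands level with compound 3 `CCC(CO)N1C(=O)NC2(CC2(C)C)C1=O` at the top of the three numbers: in a functional assay on the whole organism for inhibition, with Mus musculus as the target, in the maximal electroshock model, at a dose of 30 mg/kg by the oral route (a lower number here means a weaker effect, a higher number a stronger effect of the compound at the dose given), compound 1 gives 90% and compound 3 gives 90%, while compound 2 `CC(C)N1C(=O)NC2(CC2(C)C)C1=O` gives 70%. The step of a number 20 percentage points lower from compound 1 to compound 2 (beyond the scatter) is modest but beyond the scatter, whereas the step of no change at the digits printed from compound 1 to compound 3 (within the scatter) leaves the value where it was and the step of a number 20 percentage points higher from compound 2 to compound 3 (beyond the scatter) recovers it. Compound 4 `CC1(C)CC12NC(=O)N(Cc1ccccc1)C2=O` differs from compound 1 by phenyl in place of hydrogen on a saturated chain carbon bound to an amide-type nitrogen in a ring. Among the measured compounds shown here, no measured step touches that chain carbon; the three steps seen all exchange the whole group on the ring nitrogen. The step to compound 4 is therefore expected to be small, a number 10 percentage points lower from compound 1 to compound 4 (within the scatter), a slight loss at most. Compound 4 is estimated at 80%, within 55% to 95%.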

Compound 4, a percentage reported as inhibition, in the whole organism at one dose (the size of the read-out at that dose, not a potency): 70%
Beside the measured number, compound 4's estimate is 10 percentage points above it, within the range that was stated.
By their numbers in this assay, from the lowest: compounds 2 and 4 (each within the scatter of the next); then compounds 1 and 3 (each within the scatter of the next).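

Phenyl in place of hydrogen on a saturated chain carbon bound to an amide-type nitrogen in a ring is not a neutral change in this assay: a number 20 percentage points lower from compound 1 to compound 4 (beyond the scatter) is a modest loss. This shows that substitution at that chain carbon can affect the read-out, which the earlier exchanges of the whole group on the ring nitrogen did not test. Nothing available accounts for the loss.

As far as these compounds go, whether the loss is specific to phenyl remains open. Methyl, an amine or a pyridine ring at the same chain carbon would test this.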